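A Methoxy Group Carried Over to a Second Core

The source may report more compounds than this note shows. Statements on the series, on what has been measured and on what is new or still open speak of the compounds shown alone.

Compound 1 `CC1=CC[C@H](C(C)(C)NC(=S)N/N=C/c2ccccc2)CC1` and compound 2 `COc1ccc(/C=N/NC(=S)NC(C)(C)[C@H]2CC=C(C)CC2)cc1` differ by a single change, (methoxy in place of hydrogen on an aromatic carbon). In a functional assay on K562 cells (Homo sapiens) for inhibition, read by sulforhodamine B assay, with a stated time of 48 h (a higher number here means a weaker inhibitor of growth, a lower number a stronger inhibitor of growth), compound 1 gives 6300 nM, and compound 2 gives 1500 nM, a step of a 4.2-fold lower number from compound 1 to compound 2 (0.62 log units; beyond the scatter). Compound 3 `CC1=CC[C@H](C(C)(C)NC(=S)N/N=C(\C)c2ccccc2)CC1` rests on a different core; how its core differs from that of compound 1 is not broken down here. In this assay compound 3 gives > 100000 nM, which is a limit of the measurement rather than a number. Compound 4 `COc1ccc(/C(C)=N/NC(=S)NC(C)(C)[C@H]2CC=C(C)CC2)cc1` is compound 3 with the same change, (methoxy in place of hydrogen on an aromatic carbon). If the step seen between compound 1 and compound 2 carries over, the expected step is an at least 1.6-fold lower number from compound 3 to compound 4 (0.22 log units; that floor lies within the scatter). Because compound 3 sits at the limit of > 100000 nM in this assay, at which 1 of the 3 values shown sits, the expected value for compound 4 is 60000 nM, between 15000 nM and 200000 nM, with a real chance that only a limit is reported again.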

Compound 4, concentration for 50% growth inhibition: 54000 nM
Estimate against measurement, compound 4: 1.1-fold (0.05 log units) above; low and high end bracket the measured number.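

On the second core, the same change gives an at least 1.8-fold lower number from compound 3 to compound 4 (0.26 log units; that floor lies within the scatter). In this assay compound 3 gives > 100000 nM, which is a limit of the measurement and not a number. The result fits the change carrying over from one core to the other, but it does not show that the step has the same size on both: the same change on two cores in this assay, a 4.2-fold lower number (0.62 log units; beyond the scatter) from compound 1 to compound 2 and an at least 1.8-fold lower number (0.26 log units; that floor lies within the scatter) from compound 3 to compound 4; the limit leaves it open whether they differ

The compounds shown leave open whether a different group in place of the hydrogen, such as an amine or a carboxylic acid, would shift the number in the same way on both cores. They also leave open what a longer chain on the oxygen, such as ethoxy, would do.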